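This account rests on a few compounds, and the source may have more. Where it says the series, first, only, none or still open, it means among the compounds named here.

Working notes on the series

Compound 1 `COC(=O)C[C@@H]1C[C@@H](O)[C@H](C)[C@H](c2ccccc2)N1` is the reference point for this step. For the measured compounds named here, in a functional assay on DU-145 cells (Homo sapiens) for cytotoxicity, read by MTT assay (on this read-out lower numbers stand for stronger inhibition and higher numbers for weaker inhibition), compound 1 gives 6300 nM, the lowest of the two numbers measured so far. The other measured member, compound 2 `COC(=O)C[C@H]1C[C@H](O)[C@@H](C)[C@@H](c2ccc(C(C)C)cc2)N1`, gives in this assay 27400 nM, a number that lies above that of compound 1 by a margin beyond the scatter; no single-point difference between the two has been worked out, so only the two values are noted here.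

Compound 3 `COC(=O)C[C@H]1C[C@H](O)[C@H](C)[C@@H](c2ccccc2)N1` has not yet been measured. It is built from the same atoms and bonds as compound 1 and differs from it only in configuration: the two compounds have the same atoms and bonds and differ only in configuration as drawn: 3 of 4 stereo elements differ; a stereocentre at a saturated ring carbon is drawn S in compound 1 and R in compound 3; a stereocentre at a saturated ring carbon is drawn R in compound 1 and S in compound 3; a stereocentre at a saturated ring carbon is drawn R in compound 1 and S in compound 3. Going by the values given here, no measured pair in this set differs at a stereocentre, so there is nothing to calibrate the size of such a change against. The working expectation is that the inverted configuration at three of the four stereocentres weakens cytotoxicity, with the step from compound 1 to compound 3 estimated as a 1.9-fold higher number from compound 1 to compound 3 (0.28 log units; within the scatter), probably beyond the scatter but of uncertain size. For compound 3 in this assay the estimate is 12000 nM, with an expected range from 3000 nM to 50000 nM.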

Compound 3, half-maximal inhibitory concentration: "not active" (no number reported)
Nothing numeric was reported for compound 3; the estimate stays without a comparison.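

In this assay, for the compounds shown here, compound 3 is reported only as "not active", without a number, so no step between compound 1 and compound 3 can be read. The compounds shown leave open which of the three changed stereocentres bears on this result, and the only structural point available is this: the fact that compounds 1 and 3 differ only in the configuration as drawn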